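A few compounds are considered here, and "the series" means these few. Any claim that something is new, unique, unknown or untested is made for them only; others in the source may bear on it.

Working notes on the series.

Compound 1 `Cc1cc(C)nc(NS(=O)(=O)c2ccc(/N=C/c3c(Cl)c4cc(C(C)(C)C)cc(C(C)(C)C)c4oc3=O)cc2)n1` carries a 4,6-dimethylpyrimidin-2-yl group on the sulfonamide nitrogen; in a functional assay on MCF7 cells (Homo sapiens) for cytotoxicity, read by CCK-8 assay, with a stated time of 48 h (on this read-out lower numbers stand for stronger inhibition and higher numbers for weaker inhibition), compound 1 gives 8.8 nM. Compound 2 `Cc1cc(NS(=O)(=O)c2ccc(/N=C/c3c(Cl)c4cc(C(C)(C)C)cc(C(C)(C)C)c4oc3=O)cc2)no1` differs from it in one place only, (5-methyl-1,2-oxazol-3-yl in place of 4,6-dimethylpyrimidin-2-yl on a sulfonamide nitrogen), and in this assay compound 2 gives 64 nM. That single exchange made the step of a 7.3-fold higher number from compound 1 to compound 2 (0.86 log units; beyond the scatter).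

Compound 3 `Cc1ccc2oc(=O)c(/C=N/c3ccc(S(=O)(=O)Nc4nc(C)cc(C)n4)cc3)c(Cl)c2c1` keeps the 4,6-dimethylpyrimidin-2-yl sulfonamide but rests on a different core; the difference between the two cores is not broken down here. In this assay compound 3 gives 25 nM, which lies between the values of compound 1 and compound 2.

Compound 4 `Cc1ccc2oc(=O)c(/C=N/c3ccc(S(=O)(=O)Nc4cc(C)on4)cc3)c(Cl)c2c1` is not yet measured. It stands to compound 3 as compound 2 stands to compound 1: 5-methyl-1,2-oxazol-3-yl in place of 4,6-dimethylpyrimidin-2-yl on a sulfonamide nitrogen. The place of the change is the same in both pairs, so the same change is being made on the second core.

For compound 4 the expectation is a step of about the same size as the one seen in the first pair, a 6.8-fold higher number from compound 3 to compound 4 (0.83 log units; beyond the scatter), resting on the step of a 7.3-fold higher number from compound 1 to compound 2 (0.86 log units; beyond the scatter) and on the value of compound 3, 25 nM. Compound 4 is therefore estimated at 170 nM in this assay, with a range from 60 nM to 500 nM; whether the second core carries the change the same way remains to be seen.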

Compound 4, half-maximal inhibitory concentration: 16 nM
Compound 4: middle estimate off by 11-fold (1.03 log units), on the high side, and the stated range ends above it.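

On the core of compound 3, the exchange of 4,6-dimethylpyrimidin-2-yl for 5-methyl-1,2-oxazol-3-yl on the sulfonamide nitrogen gives a 1.6-fold lower number from compound 3 to compound 4 (0.19 log units; within the scatter), so this assay does not separate the two compounds. The exchange therefore does not carry over as a fixed step between these two cores, and a step read on one core is a poor guide to the other in this series: the same change on two cores in this assay, a 7.3-fold higher number (0.86 log units; beyond the scatter) from compound 1 to compound 2 and a 1.6-fold lower number (0.19 log units; within the scatter) from compound 3 to compound 4, 11-fold (1.06 log units) apart, beyond the scatter of two such steps. This shows that the outcome of the exchange depends on the core in these two pairs, but it does not show which part of the difference between the cores is responsible, nor does a single pair on each core give a rule for any further core.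

The compounds shown leave open which features of the two cores separate the steps. They also leave open whether another group on the sulfonamide nitrogen, such as pyridin-2-yl or a plain methyl, would give steps that differ between the cores in the same way.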